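Working notes: from compound 3 to compound 4

The source may report more compounds than this note shows. Statements on the series, on what has been measured and on what is new or still open speak of the compounds shown alone.

- compound 1 (`Cc1ccccc1-c1nc(CN2CCC(C(=O)NCCCN3CCC(C)(C)CC3)CC2)c(C)o1`) gives > 69 ug/mL as a limit
- compound 2 (`Cc1ccccc1-c1nc(CN2CCC(C(=O)NCCCN3[C@H](C)CCC[C@@H]3C)CC2)c(C)o1`) gives > 69 ug/mL as a limit
- compound 3 (`Cc1ccccc1-c1nc(CN2CCC(C(=O)NCCCN3CCCC(CC(C)C)C3)CC2)c(C)o1`) gives 54.9 ug/mL as a number

Going by the values given here, in a physicochemical assay for solubility, in phosphate buffer, measured as kinetic solubility, at pH 7.4 (on this read-out higher numbers stand for higher solubility and lower numbers for lower solubility), compound 3 gives 54.9 ug/mL as the only actual number of the three. Compound 1 and compound 2 are held by the limit of > 69 ug/mL in this assay, at which 2 of the 3 values shown sit, and give no number. Compound 4 (`Cc1ccccc1-c1nc(CN2CCC(C(=O)NCCCCN3C[C@H](C)C[C@H](C)C3)CC2)c(C)o1`) differs from compound 3 in one place (a group of 9 heavy atoms (8 carbon, 1 nitrogen; one six-membered non-aromatic ring with 1 hetero atom) in place of a group of 10 heavy atoms (9 carbon, 1 nitrogen; one six-membered non-aromatic ring with 1 hetero atom), on a saturated chain carbon, three bonds along the chain from an amide-type nitrogen). Two measured steps at that place bear on this, an at least 1.2-fold lower number from compound 1 to compound 3 (0.09 log units; that floor lies within the scatter) and an at least 1.2-fold lower number from compound 2 to compound 3 (0.09 log units; that floor lies within the scatter) as floors only, while a step that the two limits leave unreadable from compound 1 to compound 2 gives no size. No step beyond the scatter is therefore expected. The expected step, a 1.1-fold higher number from compound 3 to compound 4 (0.05 log units; within the scatter) in size, stays within the scatter. The estimate for compound 4 is 62 ug/mL as the middle, with an expected range of 35 ug/mL to 100 ug/mL on this read-out.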

Compound 4, solubility: > 71 ug/mL
Compound 4 gave a limit, no number; the forecaster's own chance of this, stated with the estimate: 40%; middle value at least 1.1-fold (0.05 log units) from the limit.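

In this assay compound 4, carrying (3,5-dimethylpiperidin-1-yl)methyl, gives > 71 ug/mL, which is a limit and not a number. Going by these compounds alone, the change at this saturated chain carbon reads as an at least 1.2-fold higher number from compound 3 to compound 4 (0.11 log units; that floor lies within the scatter), so only a floor is known, and compound 3 remains the only compound of the four with an actual number. The steps from compound 1 and compound 2 to compound 4 cannot be read, as all three values are limits: the limit of > 71 ug/mL in this assay, at which 1 of the 4 values shown sits.

From the compounds shown here alone, how far compound 1, compound 2 and compound 4 lie past their limits stays open. Also open, going by these compounds, is how a morpholine ring or a carboxylic acid at this place would read in this assay.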